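Swapping Pyrrolidinyl for Morpholinyl on the Thiocarbonyl

The source may report more compounds than this note shows. Statements on the series, on what has been measured and on what is new or still open speak of the compounds shown alone.

Three compounds were tested in a functional assay on A-431 cells (Homo sapiens) for cytotoxicity, read by MTT assay, with a stated time of 72 h, tested at 10 uM; on this read-out higher numbers stand for more inhibition of growth at the one concentration tested and lower numbers for less inhibition of growth. Compound 2 `N/C(=N\NC(=S)N1CCCC1)c1ccc(F)cn1` gives 78.7%, the highest of the three numbers. Compound 1 `N/C(=N\NC(=S)N1CCOCC1)c1ccccn1` gives 69.4%, a gap to compound 2 that stays within the usual scatter, so the two cannot be told apart. Compound 3 `Cc1cccc(/C(N)=N/NC(=S)N2CCCC2)n1` gives 67.6%, a gap beyond the scatter. Compound 4 `N/C(=N\NC(=S)N1CCOCC1)c1ccc(F)cn1` is not yet measured; it differs from compound 2 by morpholin-4-yl in place of pyrrolidin-1-yl on a thiocarbonyl carbon. Among the measured compounds shown here, no measured pair shows this change alone, though compound 1 also carries morpholin-4-yl on a different core and sits close to compound 2 in this assay. A step of no size beyond the scatter is therefore expected. Compound 4 is estimated at 71%, within a range from 56% to 84%. The expected step is a number 7.7 percentage points lower from compound 2 to compound 4 (within the scatter).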

Compound 4, percent growth inhibition at one concentration: 66.9%
Estimate against measurement, compound 4: 4.1 percentage points above; low and high end bracket the measured number.
By their numbers in this assay, from the lowest: compounds 4, 3, 1 and 2 (each within the scatter of the next, the first and the last beyond it).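

Morpholin-4-yl in place of pyrrolidin-1-yl on a thiocarbonyl carbon can now be read directly in this assay as a number 11.8 percentage points lower from compound 2 to compound 4 (beyond the scatter) on the shared core. With morpholin-4-yl held fixed, fluoro in place of hydrogen on an aromatic carbon gives a number 2.5 percentage points lower from compound 1 to compound 4 (within the scatter) and so shows no clear effect. Nothing measured here explains either step. Still open, on these data alone, is whether piperidin-1-yl or dimethylamino on the thiocarbonyl carbon would sit nearer compound 2 or compound 4. As far as these compounds go, the swap's size on the core of compound 1 also remains unknown.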